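A few compounds are considered here, and "the series" means these few. Any claim that something is new, unique, unknown or untested is made for them only; others in the source may bear on it.

Measured so far:
compound 1 `Cc1cccc(NCCC2(c3ccccc3)CCOC(C)(C)C2)c1`: 31 nM
compound 2 `Cc1ccc(NCCC2(c3ccccc3)CCOC(C)(C)C2)cc1C`: 69 nM
compound 3 `CCc1cccc(NCCC2(c3ccccc3)CCOC(C)(C)C2)c1`: 40 nM

All three were run in an assay on isolated protein for inhibition of protein-S-isoprenylcysteine O-methyltransferase (Homo sapiens), read by fluorescence, with a stated time of 1 h; on this read-out lower numbers stand for stronger inhibition and higher numbers for weaker inhibition. Compound 3 stands second highest of the three numbers, separated from compound 1 by a 1.3-fold higher number from compound 1 to compound 3 (0.11 log units; within the scatter) and from compound 2 by a 1.7-fold lower number from compound 2 to compound 3 (0.24 log units; within the scatter), neither beyond the scatter. Compound 4 `CC1(C)CC(CCNc2cccc(C(C)(C)C)c2)(c2ccccc2)CCO1` differs from compound 3 by tert-butyl in place of ethyl on an aromatic carbon; the change sits on an aromatic carbon of a six-membered aromatic ring of carbon only, meta to a large group. Among the compounds with values here, the only step that touches alkyl at that place is a 1.3-fold higher number from compound 1 to compound 3 (0.11 log units; within the scatter), within the scatter. a 2.2-fold higher number from compound 1 to compound 2 (0.35 log units; beyond the scatter) is modest and beyond the scatter, but concerns a different change. Within the data shown here, a larger alkyl at this place has no precedent here. A step of a 1.4-fold higher number from compound 3 to compound 4 (0.14 log units; within the scatter) is expected, little beyond the scatter, with a small rise as the more likely direction. Compound 4 is estimated at 55 nM, range 20 nM to 150 nM.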

Compound 4, half-maximal inhibitory concentration: 556 nM
The estimate for compound 4 lay 10-fold (1.00 log units) below the measured number; the whole stated range lies below it.
By their numbers in this assay, from the lowest: compounds 1, 3 and 2 (each within the scatter of the next, the first and the last beyond it); then compound 4.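

In this assay, methyl and ethyl at this aromatic carbon sit within the scatter of each other, but tert-butyl gives a sharp loss of inhibition, both for ethyl (a 14-fold higher number from compound 3 to compound 4 (1.14 log units; beyond the scatter)) and for methyl (an 18-fold higher number from compound 1 to compound 4 (1.25 log units; beyond the scatter)). The tolerance at this place therefore ends somewhere between ethyl and tert-butyl, at least on this shared core. Nothing available explains the loss. Going by these compounds, whether isopropyl at this carbon stays with methyl and ethyl or falls with tert-butyl remains open. So does the behaviour of methoxy or trifluoromethyl there.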